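Swapping the aryl ether of compound 1 for a cyclopropyl ether

The source may report more compounds than this note shows. Statements on the series, on what has been measured and on what is new or still open speak of the compounds shown alone.

Measured compounds:
compound 1 `Cc1cc(F)cc(C)c1Oc1ccc(C(C)(C)O)cc1-c1cn(C)c(=O)c2[nH]c(C(=O)NCc3ccc(C(=O)NO)cc3)cc12`, 39.3 nM
compound 2 `Cc1cc(F)cc(C)c1Oc1ccc(C(C)(C)O)cc1-c1cn(C)c(=O)c2[nH]c(C(=O)NCCCCCCC(=O)NO)cc12`, 17.2 nM
compound 3 `Cn1cc(-c2ccccc2Oc2ccccc2)c2cc(C(=O)NCc3ccc(C(=O)NO)cc3)[nH]c2c1=O`, 15.3 nM

In an assay on isolated protein for inhibition of protein deacetylase HDAC6 (Homo sapiens), read by fluorescence (a higher number here means a weaker inhibitor, a lower number a stronger inhibitor), compound 1 gives 39.3 nM, the highest of the three numbers. Its nearest neighbour is compound 2, reached by a 2.3-fold lower number from compound 1 to compound 2 (0.36 log units; beyond the scatter), a modest step that lies beyond the scatter. Compound 3 shares the core but differs from compound 1 in several places. In this assay compound 3 gives 15.3 nM. Among the measured compounds shown here, no single step connects compound 3 to compound 1, so its value only shows that a plain phenoxy analogue without the hydroxypropan-2-yl group sits lower than compound 1.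

Compound 4 `Cn1cc(-c2cc(C(C)(C)O)ccc2OC2CC2)c2cc(C(=O)NCc3ccc(C(=O)NO)cc3)[nH]c2c1=O` has not yet been measured. It differs from compound 1 by cyclopropyl in place of 4-fluoro-2,6-dimethylphenyl on an oxygen on an aromatic ring. For the measured compounds named here, none of the measured steps touches this position: the one step that exists, from compound 1 to compound 2, changes the hydroxamate-bearing group, not the ether. There is therefore no direct guide to the size or direction of the effect of this change. On the numbers shown, compound 4 is estimated at 30 nM, within a range of 10 nM to 100 nM, which corresponds to an expected step of a 1.3-fold lower number from compound 1 to compound 4 (0.12 log units; within the scatter), most likely not beyond the scatter.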

Compound 4, half-maximal inhibitory concentration: 7.9 nM
The estimate for compound 4 lay 3.8-fold (0.58 log units) above the measured number; measured number outside the range, below it.
By their numbers in this assay, from the lowest: compounds 4, 3 and 2 (each within the scatter of the next, the first and the last beyond it); then compound 1.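

Among the compounds shown here, until now no step had touched the ether position, and this one shows that it responds strongly to change: in this assay the swap gives a 5.0-fold lower number from compound 1 to compound 4 (0.70 log units; beyond the scatter) with cyclopropyl in place of 4-fluoro-2,6-dimethylphenyl on the oxygen. The substituted aromatic ring is therefore not needed for a low number in this series, since a three-membered non-aromatic ring of carbon only, with 3 heavy atoms against 9, does better on this core. No measurement offered here accounts for the gain, so the result stands as an observation without an explanation.

The compounds shown leave open how much of the gain depends on the ring itself, as a methyl ether, an isopropyl ether or a cyclobutyl ether on the same oxygen would show. They also leave open whether the same swap would lower the number again when the 4-(hydroxycarbamoyl)phenyl group is replaced by the 5-(hydroxycarbamoyl)pentyl group of compound 2, or whether the two changes do not add up.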